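The source may report more compounds than this note shows. Statements on the series, on what has been measured and on what is new or still open speak of the compounds shown alone.

In a functional assay on NCI-H1975 cells (Homo sapiens) for antiproliferative activity, read by MTT assay, with a stated time of 72 h (on this read-out lower numbers stand for stronger inhibition and higher numbers for weaker inhibition), compound 1 `NS(=O)(=O)c1ccc(NC(=S)Nc2ccc3ncnc(Nc4cccc(F)c4)c3c2)cc1` gives 9660 nM, while compound 2 `NS(=O)(=O)c1ccc(NC(=S)Nc2ccc3ncnc(Nc4cccc(Cl)c4)c3c2)cc1` gives 39800 nM, the higher of the two numbers, the step being a 4.1-fold higher number from compound 1 to compound 2 (0.61 log units; beyond the scatter). Compound 3 `Cc1ccc(Nc2ncnc3ccc(NC(=S)Nc4ccc(S(N)(=O)=O)cc4)cc23)cc1` differs from compound 2 by 4-methylphenyl in place of 3-chlorophenyl on a nitrogen on an aromatic ring. Within the data shown here, the one measured step concerns a different exchange at the same nitrogen and bears only loosely on this change, so neither its direction nor its size can be read directly from it. Compound 3 is expected to give 20000 nM in this assay, within 5000 nM to 80000 nM. The step of a 2.0-fold lower number from compound 2 to compound 3 (0.30 log units; within the scatter) is thus expected to stay close to the scatter.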

Compound 3, half-maximal inhibitory concentration: 39400 nM
For compound 3 the middle estimate is 2.0-fold (0.29 log units) below the measured one; the measured number falls inside the stated range.
By their numbers in this assay, from the lowest: compound 1; then compounds 3 and 2 (each within the scatter of the next).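

The read-out of this assay shows a 1.0-fold lower number from compound 2 to compound 3 (0.00 log units; within the scatter) for 4-methylphenyl in place of 3-chlorophenyl on a nitrogen on an aromatic ring, so this exchange does not separate the two compounds. Replacing 3-fluorophenyl at the same nitrogen gives a 4.1-fold higher number from compound 1 to compound 3 (0.61 log units; beyond the scatter) and leaves compound 1 as the only one of the three set apart beyond the scatter. Nothing available here explains this result. The compounds shown leave open how an unsubstituted phenyl or a 3-methoxyphenyl would read at this nitrogen.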